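A few compounds are considered here, and "the series" means these few. Any claim that something is new, unique, unknown or untested is made for them only; others in the source may bear on it.

In an ADME assay on L6 cells (Rattus norvegicus) for cytotoxicity, read by resazurin assay, with a stated time of 70 h (a lower number here means a stronger inhibitor, a higher number a weaker inhibitor), compound 1 `CC(=O)Oc1ccc2c(c1)C(C)=CC(C)(C)N2Cc1ccc(C#N)cc1` gives 29000 nM and compound 2 `CC(=O)Oc1ccc2c(c1)C(C)=CC(C)(C)N2Cc1cccc(C#N)c1` gives 31000 nM with the two values within the scatter of each other. Compound 3 `CC(=O)Oc1ccc2c(c1)C(C)=CC(C)(C)N2Cc1ccc(Cl)cc1` departs from compound 2 by one change, 4-chlorophenyl in place of 3-cyanophenyl on a saturated chain carbon bound to a nitrogen on an aromatic ring in a ring on the same saturated chain carbon. Within the data shown here, only one measured step bears on this, a 1.1-fold higher number from compound 1 to compound 2 (0.03 log units; within the scatter) and within the scatter, and it merely exchanges 4-cyanophenyl for 3-cyanophenyl. Among the measured compounds shown here, no measured step involves 4-chlorophenyl, so nothing beyond the scatter is expected in this assay for this change. The estimated move is a 1.3-fold lower number from compound 2 to compound 3 (0.11 log units; within the scatter) and no larger. Compound 3 is expected at 24000 nM with 11000 nM to 50000 nM as its range.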

Compound 3, half-maximal inhibitory concentration: 22000 nM
Compound 3: middle estimate off by 1.1-fold (0.04 log units), on the high side; the measured number falls inside the stated range.
By their numbers in this assay, from the lowest: compounds 3, 1 and 2 (each within the scatter of the next).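

In this assay, the step to 4-chlorophenyl from 3-cyanophenyl on the saturated chain carbon is a 1.4-fold lower number from compound 2 to compound 3 (0.15 log units; within the scatter), and chloro in place of cyano on an aromatic carbon is a 1.3-fold lower number from compound 1 to compound 3 (0.12 log units; within the scatter). Where the earlier compounds only exchanged 4-cyanophenyl for 3-cyanophenyl, these steps show that a phenyl ring without the nitrile also stays within the scatter at this position. No measurement at hand explains this result. The compounds shown leave open whether an amine or a carboxylic acid on this phenyl ring would give a step beyond the scatter.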